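Swapping the aryl group on compound 3

The source may report more compounds than this note shows. Statements on the series, on what has been measured and on what is new or still open speak of the compounds shown alone.

Compound 3 `C=C1CC[C@@H]2[C@](C)(COC(=O)c3cccnc3)[C@H](OC(=O)c3cccnc3)CC[C@@]2(C)[C@@H]1/C=C/C1=C/C(=C\c2cccc(Br)c2)OC1=O` gives 100% in an assay on isolated protein for inhibition of Maltase-glucoamylase (Homo sapiens), tested at 100 uM (a higher number here means more inhibition at the concentration tested (going by the name of the read-out), a lower number less inhibition), level with compound 2 `C=C1CC[C@@H]2[C@](C)(COC(=O)c3cccnc3)[C@H](OC(=O)c3cccnc3)CC[C@@]2(C)[C@@H]1/C=C/C1=C/C(=C\c2ccc(Cl)cc2)OC1=O` at 100%, the two together the highest of the three numbers; furthest away is compound 1 `C=C1CC[C@@H]2[C@](C)(COC(=O)c3cccnc3)[C@H](OC(=O)c3cccnc3)CC[C@@]2(C)[C@@H]1/C=C/C1=C/C(=C\C(C)=C\CCC/C=C/C)OC1=O` at 68.9%. The step of a number 31.1 percentage points higher from compound 1 to compound 3 (beyond the scatter) and the step of a number 31.1 percentage points higher from compound 1 to compound 2 (beyond the scatter) were both large, whereas the step of no change at the digits printed from compound 2 to compound 3 (within the scatter) stayed within the scatter. Compound 4 `C=C1CC[C@@H]2[C@](C)(COC(=O)c3cccnc3)[C@H](OC(=O)c3cccnc3)CC[C@@]2(C)[C@@H]1/C=C/C1=C/C(=C\c2ccc(N(C)C)cc2)OC1=O` differs from compound 3 by 4-(dimethylamino)phenyl in place of 3-bromophenyl on a double-bonded chain carbon bound to a double-bonded ring carbon. For the measured compounds named here, the only measured step that bears on this is the aryl-for-aryl exchange no change at the digits printed from compound 2 to compound 3 (within the scatter), which moved nothing beyond the scatter; no measured step introduces a 4-(dimethylamino)phenyl group. One therefore expects for compound 4 a step of a number 8 percentage points lower from compound 3 to compound 4 (within the scatter), at most a small fall. Compound 4 is estimated at 92%, with a range from 72% to 100%.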

Compound 4, a percentage reported as inhibition, at one concentration (the size of the read-out at that concentration, not a potency): 74.8%
The estimate for compound 4 lay 17.2 percentage points above the measured number, and the stated range covers the measured number.
By their numbers in this assay, from the lowest: compounds 1 and 4 (each within the scatter of the next); then compounds 2 and 3 (each within the scatter of the next).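

The step of a number 25.2 percentage points lower from compound 3 to compound 4 (beyond the scatter) and the step of a number 25.2 percentage points lower from compound 2 to compound 4 (beyond the scatter) show that in this assay the aryl group on this double-bonded chain carbon is not freely exchangeable, which the bromo and chloro pair had not revealed. An aromatic ring alone does not secure the high numbers, for the step of a number 5.9 percentage points higher from compound 1 to compound 4 (within the scatter) leaves compound 4 level with the open-chain compound. Nothing available explains this fall.

From the compounds shown here alone, whether the dimethylamino group itself sets the lower number remains open. A 4-methoxyphenyl or 4-aminophenyl group would help to test this.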